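Series notes: 4-aminophenyl in place of methoxy

A few compounds are considered here, and "the series" means these few. Any claim that something is new, unique, unknown or untested is made for them only; others in the source may bear on it.

Measured so far in a functional assay on MIA PaCa-2 cells (Homo sapiens) for cytotoxicity, read by MTT assay, with a stated time of 72 h; a lower number here means a stronger inhibitor, a higher number a weaker inhibitor:
compound 1, `COC(=O)c1ccc(NC2=CC(=O)c3ncncc3C2=O)cc1`: 2200 nM
compound 2, `O=C1C(Nc2ccc(Oc3ccccc3)cc2)=CC(=O)c2ncncc21`: 3700 nM
compound 3, `COc1ccc(NC2=CC(=O)c3ncncc3C2=O)cc1`: 1900 nM

Compound 3 gives the lowest of the three numbers, but none of the three stands apart: the step of a 1.2-fold lower number from compound 1 to compound 3 (0.06 log units; within the scatter) and the step of a 1.9-fold lower number from compound 2 to compound 3 (0.29 log units; within the scatter) both stay within the scatter, as does a 1.7-fold higher number from compound 1 to compound 2 (0.23 log units; within the scatter). Within this set, the group on the aromatic carbon has so far not moved the readout beyond what repeated measurement would show on its own.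

Compound 4, `Nc1ccc(-c2ccc(NC3=CC(=O)c4ncncc4C3=O)cc2)cc1`, is the next member. Its change from compound 3 is 4-aminophenyl in place of methoxy on an aromatic carbon. The step that bears most on it is a 1.9-fold lower number from compound 2 to compound 3 (0.29 log units; within the scatter), where a phenyl on the oxygen in compound 2 gave a number within the scatter of the methyl in compound 3; the step of a 1.2-fold lower number from compound 1 to compound 3 (0.06 log units; within the scatter), a second exchange of group at the same place, was likewise flat. Neither step points to a direction, so no step beyond the scatter is expected for compound 4 in this assay. The expected step is a 1.3-fold higher number from compound 3 to compound 4 (0.12 log units; within the scatter), leaning slightly toward the higher number seen for compound 2. Compound 4 is therefore estimated at 2500 nM, with a range from 900 nM to 7000 nM.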

Compound 4, half-maximal inhibitory concentration: 2500 nM
Compound 4: the middle estimate sits on the measured number at the digits printed; low and high end bracket the measured number.
By their numbers in this assay, from the lowest: compounds 3, 1, 4 and 2 (each within the scatter of the next).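

In this assay, the change from methoxy to 4-aminophenyl brings 7 heavy atoms in place of 2, adds a six-membered aromatic ring of carbon only and introduces a hydrogen-bond donor, yet the number stays flat: a 1.3-fold higher number from compound 3 to compound 4 (0.12 log units; within the scatter). The comparisons with the other two groups are equally flat, with a 1.1-fold higher number from compound 1 to compound 4 (0.06 log units; within the scatter) and a 1.5-fold lower number from compound 2 to compound 4 (0.17 log units; within the scatter), so this position, para to a large group, now holds four different groups with no step beyond the scatter, including one that extends the molecule through a directly attached aromatic ring. No measured information on the compounds bears on why the numbers stay so close together.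

The compounds shown leave open whether any group at this place can move the number beyond the scatter, for example a carboxylic acid, an amine set directly on the ring, or a longer chain. They also leave open what the amine of the 4-aminophenyl group contributes, a question that a plain phenyl at the same place would address, and whether changes to the shared core would do more than changes at this position.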